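This account rests on a few compounds, and the source may have more. Where it says the series, first, only, none or still open, it means among the compounds named here.

Measured so far in an assay on isolated protein (Cavia porcellus) with Sigma non-opioid intracellular receptor 1 (Homo sapiens) as the target, read by radioligand binding; on this read-out lower numbers stand for stronger inhibition and higher numbers for weaker inhibition:
compound 1 `CN(C)CCCCCCCCOc1ccc2oc(-c3ccccc3)cc(=O)c2c1`: 227 nM
compound 2 `CN(C)CCCCCCCCCOc1ccc2oc(-c3ccccc3)cc(=O)c2c1`: 334 nM
compound 3 `O=c1cc(-c2ccccc2)oc2ccc(OCCCCCCN3CCNC(CCO)C3)cc12`: 63 nM

Compound 3 stands at the lowest number of the three in this assay. The two steps that reach it, a 3.6-fold lower number from compound 1 to compound 3 (0.56 log units; beyond the scatter) and a 5.3-fold lower number from compound 2 to compound 3 (0.72 log units; beyond the scatter), both lie beyond the scatter, whereas the chain-lengthening step a 1.5-fold higher number from compound 1 to compound 2 (0.17 log units; within the scatter) does not. In both steps to compound 3 an open-chain dimethylamino group is exchanged for a ring amine at the chain end, and both give a lower number.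

Compound 4 `CCOC(=O)C1CCN(CCCCCCOc2ccc3oc(-c4ccccc4)cc(=O)c3c2)CC1` is not yet measured. It differs from compound 3 in one place: 4-(ethoxycarbonyl)piperidin-1-yl in place of 3-(2-hydroxyethyl)piperazin-1-yl on a saturated chain carbon, six bonds along the chain from an oxygen on an aromatic ring. For the measured compounds named here, no measured step bears directly on this exchange; the only steps that touch the chain end are the two to compound 3, and they show a ring amine in this place giving a modestly lower number than a dimethylamino group. Compound 4 keeps a ring amine in the same place, and the series holds nothing on the ethoxycarbonyl group or on the loss of the hydroxyethyl group. The step of a 1.7-fold higher number from compound 3 to compound 4 (0.24 log units; within the scatter) is therefore expected to be small, at most around the edge of the scatter, with a slightly higher number somewhat more likely than a lower one. Compound 4 is estimated at 110 nM in this assay, with a range from 40 nM to 320 nM.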

Compound 4, half-maximal inhibitory concentration: 164 nM
Compound 4: middle estimate off by 1.5-fold (0.17 log units), on the low side; the measured number falls inside the stated range.
By their numbers in this assay, from the lowest: compound 3; then compounds 4, 1 and 2 (each within the scatter of the next, the first and the last beyond it).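

In this assay, a ring amine at the chain end does not by itself carry the low number of compound 3: placing 4-(ethoxycarbonyl)piperidin-1-yl on the saturated chain carbon, six bonds along the chain from an oxygen on an aromatic ring, gives a 2.6-fold higher number from compound 3 to compound 4 (0.42 log units; beyond the scatter). The earlier advantage over the open-chain amine ends also hold only in part, since a 2.0-fold lower number from compound 2 to compound 4 (0.31 log units; beyond the scatter) lies beyond the scatter while a 1.4-fold lower number from compound 1 to compound 4 (0.14 log units; within the scatter) stays within it. Nothing measured here accounts for the gap between the two ring amines.

This exchange alters the ring's second nitrogen, removes the hydroxyethyl group and adds the ethoxycarbonyl group in one step, so the share of each remains unresolved. From the compounds shown here alone, a piperidine bearing a hydroxyethyl group, a piperazine bearing an ethoxycarbonyl group, or a carboxylic acid in place of the ester would separate these changes, and the effect of a longer chain with a ring amine at its end also remains open.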